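A nitro group on a sulfonamide: carrying one step across

The source may hold more compounds than are shown below. What is called first, only, known or untested is meant among the compounds shown, and "the series" means these compounds.

Among the compounds with values here, the three compounds measured so far share a core and differ only in the group attached to a nitrogen on an aromatic ring. Compound 2 `COc1ccc(S(=O)(=O)N2CCc3cccc(NC(=O)c4ccccc4)c32)cc1` carries a benzoyl group there, and in a functional assay on KB cells (Homo sapiens) for cytotoxicity (on this read-out lower numbers stand for stronger inhibition and higher numbers for weaker inhibition), compound 2 gives 297 nM. Compound 1 `COc1ccc(S(=O)(=O)N2CCc3cccc(NC(=O)c4ccc([N+](=O)[O-])cc4)c32)cc1` differs from compound 2 by nitro in place of hydrogen on an aromatic carbon; in this assay compound 1 gives 102 nM, which is a 2.9-fold lower number from compound 2 to compound 1 (0.46 log units; beyond the scatter). Compound 3 `COc1ccc(S(=O)(=O)N2CCc3cccc(NS(=O)(=O)c4ccccc4)c32)cc1` differs from compound 2 by phenylsulfonyl in place of benzoyl on a nitrogen on an aromatic ring, and in this assay compound 3 gives 650 nM, a change of a 2.2-fold higher number from compound 2 to compound 3 (0.34 log units; beyond the scatter). Compound 3 therefore gives the highest number of the three.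

Compound 4 `COc1ccc(S(=O)(=O)N2CCc3cccc(NS(=O)(=O)c4ccc([N+](=O)[O-])cc4)c32)cc1` has not yet been measured. It differs from compound 3 by nitro in place of hydrogen on an aromatic carbon. This is the same change, in the same place, that turns compound 2 into compound 1, and it occurs twice among these compounds. Within the data shown here, the step from compound 2 to compound 1 is the only direct guide to its size, and it was measured on a core that differs from the core of compound 3 by phenylsulfonyl in place of benzoyl on a nitrogen on an aromatic ring. Whether a sulfonamide core answers to the change in the same way as an amide core is not known from these data, so some caution is warranted.

Compound 4 is expected to give a step of about a 2.6-fold lower number from compound 3 to compound 4 (0.41 log units; beyond the scatter) in this assay, resting on compound 1 and compound 2, where the same change gave a 2.9-fold lower number from compound 2 to compound 1 (0.46 log units; beyond the scatter). Compound 4 is thus estimated at 250 nM, with the likely range from 120 nM to 550 nM.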

Compound 4, half-maximal inhibitory concentration: 1100 nM
For compound 4 the middle estimate is 4.4-fold (0.64 log units) below the measured one, outside the stated range (above it).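

In this assay, the nitro group that helped on the amide core does not do the same on the sulfonamide core: phenyl to 4-nitrophenyl gives (a 1.7-fold higher number from compound 3 to compound 4 (0.23 log units; within the scatter)), a step too small to tell apart from the differences seen between repeated measurements, so compound 3 and compound 4 cannot be ranked against each other. The size of the step seen on one core therefore does not carry over to the other, and the benefit seen with compound 1 cannot be assumed for a sulfonamide in this series: the same change on two cores in this assay, a 2.9-fold lower number (0.46 log units; beyond the scatter) from compound 2 to compound 1 and a 1.7-fold higher number (0.23 log units; within the scatter) from compound 3 to compound 4, 4.9-fold (0.69 log units) apart, beyond the scatter of two such steps.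
Within the data shown here, this does not explain why the two cores part ways, and with only one pair on each core it cannot show how the nitro change would behave on any further core, or whether the gap would hold up in other assays.

The compounds shown leave open whether this split belongs to the nitro group alone or would also appear with other groups in its place, such as an amine or a carboxylic acid. They also leave open what a longer chain between the nitrogen and the phenyl ring would do to the same change.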